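The source may hold more compounds than are shown below. What is called first, only, known or untested is meant among the compounds shown, and "the series" means these compounds.

Measured compounds, in an assay on membranes from liver for displacement of a labelled ligand from Glucagon receptor (Mus musculus), read by scintillation counting, with a stated time of 60 min; a lower number here means a stronger inhibitor, a higher number a weaker inhibitor:
compound 1 `C[C@H](c1ccc(C(=O)NCCC(=O)O)cc1)N1C(=O)C(c2ccc(F)cc2)=N[C@]12CC[C@@H](C(C)(C)C)CC2` gives 2500 nM
compound 2 `C[C@H](c1ccc(C(=O)NCCC(=O)O)cc1)N1C(=O)C(c2cccc(C3CC3)c2)=N[C@]12CC[C@@H](C(C)(C)C)CC2` gives 1700 nM
compound 3 `C[C@H](c1ccc(C(=O)NCCC(=O)O)cc1)N1C(=O)C(c2ccccc2F)=N[C@]12CC[C@@H](C(C)(C)C)CC2` gives > 10000 nM, which is a limit of the assay and not a number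

Compound 3 therefore stands apart from the other two: only a limit is known for it, and that limit is the limit of > 10000 nM in this assay, at which 1 of the 3 values shown sits. The two measured steps that reach it, an at least 4.0-fold higher number from compound 1 to compound 3 (0.60 log units; beyond the scatter) and an at least 5.8-fold higher number from compound 2 to compound 3 (0.76 log units; beyond the scatter), are both beyond the scatter, while a 1.5-fold lower number from compound 1 to compound 2 (0.17 log units; within the scatter) is within it.

Compound 4 `C[C@H](c1ccc(C(=O)NCCC(=O)O)cc1)N1C(=O)C(c2cccc(Cl)c2F)=N[C@]12CC[C@@H](C(C)(C)C)CC2` is not yet measured. It differs from compound 3 in one place: chloro in place of hydrogen on an aromatic carbon. Going by the values given here, no measured step changes a substituent on the 2-fluorophenyl ring, so nothing measured bears directly on this change. What the steps do show is that both compounds carrying a 2-fluorophenyl on the carbon with a double bond to nitrogen sit at the limit, and the added chloro is a single heavy atom without donors or acceptors. With compound 3 at a limit, the step of a number no higher from compound 3 to compound 4 (the limit leaves the size open) is expected to stay small and the number for compound 4 to remain at or near the limit; it is estimated as 10000 nM, within a range of 3000 nM to 30000 nM.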

Compound 4, half-maximal inhibitory concentration: 4000 nM
Estimate against measurement, compound 4: 2.5-fold (0.40 log units) above; measured number inside the range.
By their numbers in this assay, from the lowest: compounds 2, 1 and 4 (each within the scatter of the next, the first and the last beyond it). At a limit, above all of these: compound 3.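

In this assay compound 3 has only a limit and not a number: the limit of > 10000 nM in this assay, at which 1 of the 4 values shown sits. Chloro in place of hydrogen on the aromatic carbon ortho to the fluoro group gives an at least 2.5-fold lower number from compound 3 to compound 4 (0.39 log units; beyond the scatter), so the first substituent change shown on the 2-fluorophenyl ring brings this subseries off the limit, and this position accepts the added chlorine atom without loss in this assay. The gain remains partial: the 3-chloro-2-fluorophenyl group falls short of the 3-cyclopropylphenyl group, with a 2.4-fold higher number from compound 2 to compound 4 (0.37 log units; beyond the scatter), and cannot be told apart from the 4-fluorophenyl group, with a 1.6-fold higher number from compound 1 to compound 4 (0.20 log units; within the scatter).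

The compounds shown leave open whether the fluoro group contributes to this result at all, which a ring carrying the chloro group alone would test, and whether a cyclopropyl group at the same position with the fluoro group kept would give a lower number than chloro does. They also leave open how far this position extends to other groups, such as a bromo, a methoxy or an amine, and whether the chloro step would hold with anything other than the shared core.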